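The source may hold more compounds than are shown below. What is called first, only, known or untested is meant among the compounds shown, and "the series" means these compounds.

Measured compounds in this study:

compound 1 `C=C1C[C@]23C[C@@]1(O)CC[C@H]2c1ccc(OS(=O)(=O)c2ccc(C)cc2)c(C)c1[C@@H]3Cn1cc(-c2ccc(Br)cc2)nn1` — > 20000 nM, a limit of the assay
compound 2 `C=C1C[C@]23C[C@@]1(O)CC[C@H]2c1ccc(OS(=O)(=O)c2ccc(C)cc2)c(C)c1[C@@H]3Cn1cc(-c2ccc(OC)cc2)nn1` — > 20000 nM, a limit of the assay
compound 3 `COc1ccc(-c2cn(C[C@H]3c4c(ccc(OS(=O)(=O)c5ccc(C)cc5)c4C)[C@@H]4CC[C@@]5(C)C[C@]43CC5=O)nn2)cc1` — > 20000 nM, a limit of the assay

In a functional assay on HL-60 cells (Homo sapiens) for cytotoxicity, read by MTT assay, with a stated time of 4 days (on this read-out higher numbers stand for weaker inhibition and lower numbers for stronger inhibition), compound 1 gives > 20000 nM, which is a limit of the assay rather than a number. Compound 2 likewise gives > 20000 nM, again a limit. Compound 3 gives > 20000 nM, also a limit. The change from compound 2 to compound 1 is bromo in place of methoxy on an aromatic carbon; the step that the two limits leave unreadable from compound 2 to compound 1 is one that the two limits leave unreadable. Compound 3 and compound 2 are built from the same atoms joined differently; the difference between the two cores is not broken down here.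

Compound 4 `Cc1ccc(S(=O)(=O)Oc2ccc3c(c2C)[C@H](Cn2cc(-c4ccc(Br)cc4)nn2)[C@@]24CC(=O)[C@@](C)(CC[C@@H]32)C4)cc1` has not yet been measured in this assay. It differs from compound 3 by bromo in place of methoxy on an aromatic carbon, the same change, at the same place, as that from compound 2 to compound 1. The expectation for compound 4 rests on (the limit of > 20000 nM in this assay, at which 3 of the 3 values shown sit). With every measured compound at that limit, the step is expected to be a step that the limit leaves unreadable from compound 3 to compound 4, set beside the earlier unreadable one. Compound 4 is therefore expected to give 30000 nM, most probably reported again only as a limit, within a range from 8000 nM to 100000 nM.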

Compound 4, half-maximal inhibitory concentration: > 20000 nM
Compound 4: a limit, no number; the forecaster's own chance of this, stated with the estimate: 85%; the middle value is on the limit's open side.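

In this assay compound 4 gives > 20000 nM, a limit of the assay and not a number. Among these compounds, the change from compound 3 to compound 4 therefore yields no readable step, and no new step can be drawn. The compounds shown leave open how methoxy and bromo compare here, and how the two cores compare.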